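This account rests on a few compounds, and the source may have more. Where it says the series, first, only, none or still open, it means among the compounds named here.

Compound 3 `COc1cccc(/C=N/NC(=O)CSc2nnc(-c3ccncc3)o2)c1` gives 13800 nM in a functional assay on MCF7 cells (Homo sapiens) for cytotoxicity, read by MTT assay, with a stated time of 48 h (on this read-out lower numbers stand for stronger inhibition and higher numbers for weaker inhibition), the lowest of three numbers, though its neighbours lie within the usual scatter: compound 1 `O=C(CSc1nnc(-c2ccncc2)o1)N/N=C/c1ccccc1` gives 14600 nM and compound 2 `Cc1ccc(/C=N/NC(=O)CSc2nnc(-c3ccncc3)o2)cc1` gives 14700 nM. The step from compound 3 to compound 4 `O=C(CSc1nnc(-c2ccncc2)o1)N/N=C/c1cc(Cl)ccc1O` is 5-chloro-2-hydroxyphenyl in place of 3-methoxyphenyl on a carbon with a double bond to nitrogen. Among the measured compounds shown here, no measured step tests a hydroxy or a chloro group on this ring, so the comparison rests on what the aryl ring tolerated so far. The three measured steps all changed substituents on that ring, and each stayed within the scatter: a 1.0-fold higher number from compound 1 to compound 2 (0.00 log units; within the scatter), a 1.1-fold lower number from compound 1 to compound 3 (0.02 log units; within the scatter) and a 1.1-fold lower number from compound 2 to compound 3 (0.03 log units; within the scatter). On that basis no step beyond the scatter is expected in this assay for compound 4, in either direction, though the entering group differs more from its predecessors than any earlier exchange did, which widens the range. Compound 4 is therefore estimated at 13000 nM, between 5000 nM and 35000 nM, a step of a 1.1-fold lower number from compound 3 to compound 4 (0.03 log units; within the scatter).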

Compound 4, half-maximal inhibitory concentration: 5830 nM
For compound 4 the middle estimate is 2.2-fold (0.35 log units) above the measured one; low and high end bracket the measured number.
By their numbers in this assay, from the lowest: compound 4; then compounds 3, 1 and 2 (each within the scatter of the next).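

In this assay the position on the carbon with a double bond to nitrogen, where methyl and methoxy stayed within the scatter, does respond to a change of aryl group: 5-chloro-2-hydroxyphenyl gives a 2.4-fold lower number from compound 3 to compound 4 (0.37 log units; beyond the scatter), and likewise a 2.5-fold lower number from compound 2 to compound 4 (0.40 log units; beyond the scatter) and a 2.5-fold lower number from compound 1 to compound 4 (0.40 log units; beyond the scatter). Compound 4 is the only one of the four whose steps to all the others lie beyond the scatter, and its aryl group is the only one counted with a hydrogen-bond donor, though hydroxy and chloro enter together. Nothing measured here explains this step.

The compounds shown leave open whether the hydroxy group or the chlorine alone carries the step. They also leave open what an amine or a carboxylic acid on this ring would do in this assay.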